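Swapping a Sulfonamide Tail for a Carbamate Chain

The compounds below may be only part of what the source reports. "The series", "measured", "known", "first", "only" and "open" are said of these compounds alone.

In an assay for inhibition of apolipoprotein B-100 (Homo sapiens), tested at 100 nM (a lower number here means a stronger inhibitor, a higher number a weaker inhibitor), compound 2 `Cc1cccc(C(=O)Nc2ccc3c(c2)CC(CNS(C)(=O)=O)C3)c1-c1ccc(C(F)(F)F)cc1` gives 6.5 nM, the lowest of the three numbers available. Compound 3 `Cc1cccc(C(=O)Nc2ccc3c(c2)CC(CNS(C)(=O)=O)C3)c1-c1ccc(Cl)cc1` gives 16 nM, and compound 1 `CN(C)C(=O)NC1Cc2ccc(NC(=O)c3ccccc3-c3ccc(C(F)(F)F)cc3)cc2C1` gives 120 nM. For the measured compounds named here, the only single-point comparison, a 2.5-fold higher number from compound 2 to compound 3 (0.39 log units; beyond the scatter), concerns the aromatic substituent and not the side chain. Compound 4 `COC(=O)NCCC1Cc2ccc(NC(=O)c3cccc(C)c3-c3ccc(C(F)(F)F)cc3)cc2C1` differs from compound 2 by ((methoxycarbonyl)amino)methyl in place of methanesulfonamido on a saturated chain carbon bound to a saturated ring carbon. Compound 1 carries a different chain as well, but it differs from compound 2 in more than one place, so its number cannot be read as a chain effect alone. Going by the values given here, with no measured step bearing directly on this change, the expected outcome is a modest rise in the number, a 2.3-fold higher number from compound 2 to compound 4 (0.36 log units; beyond the scatter). Compound 4 is therefore estimated at 15 nM, plausibly between 4 nM and 50 nM.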

Compound 4, half-maximal inhibitory concentration: 10 nM
Estimate against measurement, compound 4: 1.5-fold (0.18 log units) above, and the stated range covers the measured number.
By their numbers in this assay, from the lowest: compounds 2, 4 and 3 (each within the scatter of the next, the first and the last beyond it); then compound 1.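

For the compounds shown here, this is the first comparison of side chains that differ in one place only, and in this assay the exchange of (methanesulfonamido)methyl for 2-((methoxycarbonyl)amino)ethyl gives a 1.5-fold higher number from compound 2 to compound 4 (0.19 log units; within the scatter). So on this saturated ring carbon, the sulfur-containing group can be replaced, with one carbon more in the chain, without a change beyond the scatter. No available evidence explains why the two chains read alike. Still open, on these data alone, is how a free amine, a carboxylic acid or a longer chain would read here, and whether this exchange gives a similar result with chloro in place of trifluoromethyl.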